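This account rests on a few compounds, and the source may have more. Where it says the series, first, only, none or still open, it means among the compounds named here.

Compound 1 `CSc1nc(-c2cccs2)c(C#N)c(=O)n1C` gives 83 ug/mL in a functional assay on microsomes for inhibition, with a stated time of 1 h; on this read-out higher numbers stand for weaker inhibition and lower numbers for stronger inhibition.
Compound 2 `CCOC(=O)c1cnn(-c2nc(-c3ccccc3Cl)c(C#N)c(=O)n2C)c1N` gives 102 ug/mL in this assay.
Compound 3 `Cn1c(NN)nc(-c2ccco2)c(C#N)c1=O` gives 78 ug/mL in this assay.

Among these three, compound 2 has the highest number in this assay, but the gap to compound 1 and the gap to compound 3 both lie within the usual scatter, so the three compounds cannot be told apart on these numbers.

Compound 4 `CCOC(=O)c1cnn(-c2nc(-c3cccs3)c(C#N)c(=O)n2C)c1N` shares the core of compound 2 and differs from it in one place: thiophen-2-yl in place of 2-chlorophenyl on an aromatic carbon. Within the data shown here, no measured pair of compounds shows the effect of this change on its own. Compound 1 also carries a thiophen-2-yl group on the same core, though it differs from compound 2 in other places as well, and its value in this assay sits close to that of compound 2. With all three measured numbers clustered within the scatter, the step from compound 2 to compound 4 is expected to be small, with no direction beyond the scatter, as a 1.1-fold lower number from compound 2 to compound 4 (0.05 log units; within the scatter). Compound 4 is therefore estimated to give 90 ug/mL in this assay, expected to fall between 45 ug/mL and 180 ug/mL.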

Compound 4, half-maximal inhibitory concentration: 97 ug/mL
Compound 4: middle estimate off by 1.1-fold (0.03 log units), on the low side; the range from low to high includes it.
By their numbers in this assay, from the lowest: compounds 3, 1, 4 and 2 (each within the scatter of the next).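

Among these compounds, the pair gives the first direct reading of this position. In this assay, placing thiophen-2-yl instead of 2-chlorophenyl on the aromatic carbon ortho to the cyano group gives a 1.1-fold lower number from compound 2 to compound 4 (0.02 log units; within the scatter), so exchanging the six-membered carbon ring and its chlorine for a five-membered ring with one hetero atom leaves the two compounds indistinguishable. Nothing at hand offers an explanation for this result.

Going by these compounds, only these two aryl groups have been compared at this position with the rest of the structure held the same, so it remains open whether an amine, a carboxylic acid or a longer chain there would shift the number beyond the scatter. On these data alone, it is equally open whether the same exchange would give a similar result with a different group in place of the aminopyrazole-free substituents of the other compounds.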